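The compounds below may be only part of what the source reports. "The series", "measured", "known", "first", "only" and "open" are said of these compounds alone.

Working notes on the series. In a functional assay on SW-620 cells (Homo sapiens) for antiproliferative activity, read by MTT assay, with a stated time of 24 h (a lower number here means a stronger inhibitor, a higher number a weaker inhibitor), compound 1 `COc1nc(C)c(CCO)c(OC)n1` gives only a limit, > 100000 nM. Compound 2 `COc1nc(Cl)nc(C)c1CCO` likewise gives only a limit in this assay, > 100000 nM. The step that the two limits leave unreadable from compound 1 to compound 2, chloro in place of methoxy on an aromatic carbon, stands against the limit of > 100000 nM in this assay, at which 2 of the 3 values shown sit, and so carries no readable size. Among the measured compounds shown here, compound 3 `COc1ccc(C(OCCc2c(C)nc(OC)nc2OC)(c2ccccc2)c2ccccc2)cc1` gives 20000 nM in this assay; no single-point step connects it to the others. Compound 4 `COc1nc(Cl)nc(C)c1CCF` differs from compound 2 by fluoro in place of hydroxy on a saturated chain carbon, two bonds along the chain from an aromatic carbon. For the measured compounds named here, no measured step bears on this change, and the only step among the measured compounds is unreadable, so nothing sets an expected size or direction in this assay. Compound 4 is therefore expected at 100000 nM, within 30000 nM to 300000 nM. The expected step is a number no higher from compound 2 to compound 4 (the limit leaves the size open), most likely again only a limit.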

Compound 4, half-maximal inhibitory concentration: > 100000 nM
Compound 4 was reported as a limit; the forecaster's own chance of this, stated with the estimate: 80%; the middle value lies on the limit itself.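

No size can be read for the step between compound 2 and compound 4 in this assay, which stands against the limit: the limit of > 100000 nM in this assay, at which 3 of the 4 values shown sit. The compounds shown leave open whether fluoro in place of hydroxy on this chain changes antiproliferative activity at all.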